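Pyridin-4-yl in Place of 4-Chlorophenyl on the Carbonyl Carbon

This account rests on a few compounds, and the source may have more. Where it says the series, first, only, none or still open, it means among the compounds named here.

Compound 1 `CCC(=O)N1CCCn2nc(COc3ccccc3)cc21`: 48%
Compound 2 `O=C(c1ccc(Cl)cc1)N1CCCn2nc(COc3ccccc3)cc21`: 68%

Both compounds share one core and differ only in the group on the carbonyl carbon. In a functional assay on HEK293 cells for positive allosteric modulation of metabotropic glutamate receptor 5 (Homo sapiens), read by calcium flux (on this read-out higher numbers stand for larger maximal responses and lower numbers for smaller maximal responses), compound 2 gives 68%, the higher of the two numbers; the step of a number 20 percentage points higher from compound 1 to compound 2 (beyond the scatter) lies beyond the scatter. Compound 3 `O=C(c1ccncc1)N1CCCn2nc(COc3ccccc3)cc21` carries the change (pyridin-4-yl in place of 4-chlorophenyl on a carbonyl carbon). For the measured compounds named here, no measured step swaps one six-membered aromatic ring for another, so the single known step only shows that this position matters. A small drop or no change beyond the scatter is expected, namely a number 13 percentage points lower from compound 2 to compound 3 (beyond the scatter). Compound 3 is estimated at 55%, between 35% and 75%.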

Compound 3, largest response reached (reported as percent of maximum), in percent of the reference or control that the assay uses: 51%
Beside the measured number, compound 3's estimate is 4 percentage points above it; the measured number falls inside the stated range.
By their numbers in this assay, from the lowest: compounds 1 and 3 (each within the scatter of the next); then compound 2.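

In this assay, the ring on the carbonyl carbon cannot be swapped freely: pyridin-4-yl in place of 4-chlorophenyl gives a clear loss (a number 17 percentage points lower from compound 2 to compound 3 (beyond the scatter)). The higher number of compound 2 therefore does not come with just any six-membered aromatic ring. Pyridin-4-yl also shows no separation from ethyl (a number 3 percentage points higher from compound 1 to compound 3 (within the scatter)). Nothing available here explains these results. Still open, going by these compounds, is whether the chlorine or the carbon-only ring matters more; phenyl without chlorine, or 4-methoxyphenyl, would test this.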